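Adding a 4-chlorophenyl to a compound at the limit

A few compounds are considered here, and "the series" means these few. Any claim that something is new, unique, unknown or untested is made for them only; others in the source may bear on it.

In a physicochemical assay for solubility, measured as kinetic solubility (on this read-out higher numbers stand for higher solubility and lower numbers for lower solubility), compound 2 `CNc1ccnc2c(O)c(-c3nc(C)n[nH]3)ncc12` gives > 250000 nM as its reading, and this is a limit, not a number. Compound 1 `Cc1n[nH]c(-c2ncc3cccnc3c2O)n1` gives > 250000 nM and this too is a limit. Compound 3 `Cc1n[nH]c(-c2ncc3c(N(C)C)ccnc3c2O)n1` gives > 250000 nM and this is likewise a limit.

Compound 4 `Cc1n[nH]c(-c2ncc3c(NCc4ccc(Cl)cc4)ccnc3c2O)n1` differs from compound 2 by 4-chlorophenyl in place of hydrogen on a saturated chain carbon bound to a nitrogen on an aromatic ring in one place: 4-chlorophenyl stands in place of hydrogen on a saturated chain carbon bound to a nitrogen on an aromatic ring, so methyl becomes 4-chlorobenzyl.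

The measured steps that bear on this are a step that the two limits leave unreadable from compound 1 to compound 2 and a step that the two limits leave unreadable from compound 1 to compound 3 and a step that the two limits leave unreadable from compound 2 to compound 3 and none of them has a readable size. They therefore offer no measured guide to this much larger change. A cautious fall in solubility is expected in this assay and the estimated change is an at least 2.0-fold lower number from compound 2 to compound 4 (0.31 log units; beyond the scatter) on this uncertain basis. For compound 4 the expected value is 120000 nM with an estimated range from 30000 nM to 250000 nM in this measurement.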

Compound 4, solubility: 219000 nM
Compound 4: the middle estimate sits 1.8-fold (0.26 log units) below what was measured; the measured number falls inside the stated range.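

In this assay, compound 4 gives 219000 nM, the only reading shown that is a number and not a limit, so the place on the saturated chain carbon bound to a nitrogen on an aromatic ring now has one measured value to work from. Changing methyl to 4-chlorobenzyl gives an at least 1.1-fold lower number from compound 2 to compound 4 (0.05 log units; that floor lies within the scatter), which means the data secure only a floor for this change and that floor does not clear the usual scatter. The real size of the step cannot be read because the reading of compound 2 is a limit: the limit of > 250000 nM in this assay, at which 3 of the 4 values shown sit.

The steps among compound 1, compound 2 and compound 3 cannot be read either, so the shown compounds do not rank those three. Also open, as far as these compounds go, is how an unsubstituted benzyl, a longer chain or a chain ending in an amine or a carboxylic acid would read in place of the 4-chlorobenzyl.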